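Halogen exchange on the phenyl group of compound 3

The compounds below may be only part of what the source reports. "The series", "measured", "known", "first", "only" and "open" are said of these compounds alone.

Measured compounds in a functional assay on the whole organism (strain CD1) with Mus musculus as the target, in the maximal electroshock model, with a stated time of 0.5 h; on this read-out higher numbers stand for an effect only at larger amounts of compound and lower numbers for an effect already at smaller amounts:
- compound 1 `CC1CC(=O)N(CC(=O)N2CCN(c3ccccc3)CC2)C1=O`: 300 mg/kg
- compound 2 `CC1CC(=O)N(CC(=O)N2CCN(c3ccccc3F)CC2)C1=O`: 300 mg/kg
- compound 3 `CC1CC(=O)N(CC(=O)N2CCN(c3ccc(F)cc3)CC2)C1=O`: 300 mg/kg

Compound 3 stands level with the other two measured compounds: the step of no change at the digits printed from compound 1 to compound 3 (within the scatter) and the step of no change at the digits printed from compound 2 to compound 3 (within the scatter) are both flat, as is the step of no change at the digits printed from compound 1 to compound 2 (within the scatter) between the two compounds around it. Across the three, neither the presence of fluorine on the ring nor its position on the ring has moved the read-out.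

The next compound, compound 4 `CC1CC(=O)N(CC(=O)N2CCN(c3ccccc3Cl)CC2)C1=O`, differs from compound 3 by 2-chlorophenyl in place of 4-fluorophenyl on an amine nitrogen in a ring.

All three measured steps bear on this change in a loose way: each exchanges a hydrogen or a fluorine on the same phenyl group, and none shifts the read-out beyond the scatter. Among the measured compounds shown here, no measured step introduces chlorine, so the effect of that atom is unknown here. On the evidence of the flat steps, compound 4 is expected to sit at the same level, with an estimated step of no change at the digits printed from compound 3 to compound 4 (within the scatter) that is within the scatter. Compound 4 is therefore estimated at 300 mg/kg, with a range from 100 mg/kg to 600 mg/kg.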

Compound 4, minimum effective dose: 300 mg/kg
Compound 4: the middle estimate sits on the measured number at the digits printed; the measured number falls inside the stated range.
By their numbers in this assay, from the lowest: compounds 1, 2, 3 and 4 (each within the scatter of the next).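

Chlorine on the phenyl group is new in this series, and 2-chlorophenyl in place of 4-fluorophenyl leaves the read-out in this assay flat (no change at the digits printed from compound 3 to compound 4 (within the scatter)). The picture is the same for chloro in place of fluoro on an aromatic carbon (no change at the digits printed from compound 2 to compound 4 (within the scatter)) and for chloro in place of hydrogen (no change at the digits printed from compound 1 to compound 4 (within the scatter)), so at this position the phenyl group has so far tolerated hydrogen, fluoro and chloro without any step beyond the scatter. No independent data are at hand to explain this flatness.

As far as these compounds go, it remains open whether 4-chlorophenyl, or a trifluoromethyl or methoxy group on the phenyl group, would move the read-out. Also open, from the compounds shown here alone, is whether a longer chain in place of the methyl group on the shared core would shift it.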